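Serum half-life of two nitrooxy esters on different cores

The source may hold more compounds than are shown below. What is called first, only, known or untested is meant among the compounds shown, and "the series" means these compounds.

Compound 1 `Cc1cc(OC(=O)C(C)(C)CCC(CO[N+](=O)[O-])O[N+](=O)[O-])n(-c2ccccc2)n1` and compound 2 `Cc1cc(OC(=O)C(C)(C)CCCCO[N+](=O)[O-])n(-c2ccccc2)n1` share one core, while compound 3 `Cc1cc(OC(=O)c2ccc(OCC(CO[N+](=O)[O-])O[N+](=O)[O-])cc2)n(-c2ccccc2)n1` and compound 4 `Cc1cc(OC(=O)c2ccc(OCCCO[N+](=O)[O-])cc2)n(-c2ccccc2)n1` share another; the difference between the two cores is not broken down here. In an ADME assay on a cell-free system (serum, Homo sapiens) for metabolic stability, read by HPLC, tested at 250 uM (on this read-out lower numbers stand for a shorter-lived compound and higher numbers for a longer-lived compound), compound 1 gives 0.27 h, and compound 2 gives 0.222 h. The change between them, (hydrogen in place of nitrooxy on a saturated chain carbon bound to two saturated chain carbons), produced a 1.2-fold lower number from compound 1 to compound 2 (0.09 log units; within the scatter). In this assay compound 3 gives 0.13 h. Compound 4 carries the same change relative to compound 3, (hydrogen in place of nitrooxy on a saturated chain carbon bound to two saturated chain carbons), on the other core. Because the earlier pair showed a 1.2-fold lower number from compound 1 to compound 2 (0.09 log units; within the scatter), compound 4 is expected to give a 1.2-fold lower number from compound 3 to compound 4 (0.07 log units; within the scatter). Compound 4 is therefore estimated at 0.11 h, with a range from 0.06 h to 0.22 h expected.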

Compound 4, half-life in the serum assay: 0.0833 h
Beside the measured number, compound 4's estimate is 1.3-fold (0.12 log units) above it; low and high end bracket the measured number.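

In the serum assay, hydrogen in place of nitrooxy on a saturated chain carbon bound to two saturated chain carbons gave a 1.6-fold lower number from compound 3 to compound 4 (0.19 log units; within the scatter), and this step agrees with the one on the other core: the same change on two cores in the serum assay, a 1.2-fold lower number (0.09 log units; within the scatter) from compound 1 to compound 2 and a 1.6-fold lower number (0.19 log units; within the scatter) from compound 3 to compound 4, 1.3-fold (0.11 log units) apart, within the scatter of two such steps. The change therefore carried from one core to the other without a readable difference, but neither step stands clear of the scatter, and two pairs show agreement only for these cores, not a rule for the series. In a physicochemical assay for lipophilicity, read by HPLC, measured as octanol-water partition, at pH 7 (a higher number here means a more lipophilic compound, a lower number a more polar compound), compound 3 gives 5.14 and compound 4 gives 4.74, and the change does register on the core of compound 3: the measured partition coefficient of compound 3, 5.14, and of compound 4, 4.74, a number 0.40 log units lower (beyond the scatter).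

The compounds shown leave open whether this agreement would hold for a longer chain carrying the nitrooxy, or for an amine or a carboxylic acid in place of nitrooxy on that carbon. They also leave open whether it extends to a third core.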